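Exchanging the aryl group on the compound 3 core

A few compounds are considered here, and "the series" means these few. Any claim that something is new, unique, unknown or untested is made for them only; others in the source may bear on it.

In a functional assay on HCT-116 cells (Homo sapiens) for antiproliferative activity, read by MTT assay, with a stated time of 72 h (a higher number here means a weaker inhibitor, a lower number a stronger inhibitor), compound 3 `NC1=NC2(CCOCC2)N(OCCCOc2ccc(Cl)cc2)C(N)=N1` gives 690 nM and holds the highest of the three numbers available, which makes it the weakest inhibitor among them. In this assay compound 1 `CC(C)(C)c1ccc(OCCCON2C(N)=NC(N)=NC23CCSCC3)cc1` gives 1 nM and compound 2 `NC1=NC2(CCSCC2)N(OCCCOc2cccc(Cl)c2)C(N)=N1` gives 1 nM so these two read alike, and both lie far beyond the scatter from compound 3.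

Compound 4 `Cc1cc(C)cc(OCCCON2C(N)=NC(N)=NC23CCOCC3)c1` has not yet been measured. It carries 3,5-dimethylphenyl in place of 4-chlorophenyl on an oxygen on a saturated carbon and otherwise matches compound 3. For the measured compounds named here, no measured pair isolates this exchange, so the data do not give its size directly. Going by the values given here, the only measured compound with the same core as compound 4 is compound 3 at 690 nM and the expectation therefore stays close to that number. The estimated step in this assay is a 1.7-fold lower number from compound 3 to compound 4 (0.24 log units; within the scatter) toward a lower number, and no change beyond the scatter is expected. The uncertainty remains wide, since a single measured compound anchors the expectation. For compound 4 the estimated value is 400 nM with an expected range of 80 nM to 2000 nM in this measurement.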

Compound 4, half-maximal inhibitory concentration: 190 nM
Compound 4: middle estimate off by 2.1-fold (0.32 log units), on the high side, and the stated range covers the measured number.
By their numbers in this assay, from the lowest: compounds 1 and 2 (each within the scatter of the next); then compound 4; then compound 3.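

In this assay, the exchange of 4-chlorophenyl for 3,5-dimethylphenyl on an oxygen on a saturated carbon gives a 3.6-fold lower number from compound 3 to compound 4 (0.56 log units; beyond the scatter), with the rest of the molecule unchanged. For the compounds shown here, this is the first measured sign that the aryl group at this place alone can move the number beyond the scatter, although the step is modest. Both groups are a six-membered aromatic ring of carbon only, with no hydrogen-bond donors or acceptors and no net charge, and nothing available accounts for the step.

This single exchange leaves open whether the step follows from losing the chlorine or from gaining the two methyl groups, and a plain phenyl or a pyridyl group at the same place would help separate the two. Going by these compounds, compound 1 and compound 2 differ from compound 3 and compound 4 in more than one place, so those steps cannot be read, and it remains open how much of their separation belongs to the core and how much to the aryl group.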